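Swapping the oxadiazole isomer on the piperazine nitrogen

A few compounds are considered here, and "the series" means these few. Any claim that something is new, unique, unknown or untested is made for them only; others in the source may bear on it.

Compound 3 `CCN(CC)S(=O)(=O)c1ccc(S(=O)(=O)N2CCC[C@@H](C(=O)N3CCN(c4nnc(C(C)C)o4)CC3)C2)cc1` gives 1000 nM in a functional assay on MIA PaCa-2 cells (Homo sapiens) for inhibition, read by MTT assay, with a stated time of 3 days (a higher number here means a weaker inhibitor, a lower number a stronger inhibitor), the highest of the three values. Compound 1 `CC(C)c1noc(N2CCN(C(=O)[C@@H]3CCCN(S(=O)(=O)c4ccc(S(=O)(=O)C(C)C)cc4)C3)CC2)n1` gives 30 nM, and compound 2 `CCN(CC)S(=O)(=O)c1ccc(S(=O)(=O)N2CCC[C@@H](C(=O)N3CCN(C(=O)OC(C)(C)C)CC3)C2)cc1` gives 10 nM. Going by the values given here, the only one-place step, a 100-fold higher number from compound 2 to compound 3 (2.00 log units; beyond the scatter), shows how much the oxadiazole group cost. Compound 4 `CCN(CC)S(=O)(=O)c1ccc(S(=O)(=O)N2CCC[C@@H](C(=O)N3CCN(c4nc(C(C)C)no4)CC3)C2)cc1` differs by 3-isopropyl-1,2,4-oxadiazol-5-yl in place of 5-isopropyl-1,3,4-oxadiazol-2-yl on an amine nitrogen in a ring. Among the compounds with values here, no measured step tests this isomer swap directly; compound 1, which carries the same 3-isopropyl-1,2,4-oxadiazol-5-yl group but a different sulfonyl end, gives 30 nM, so the entering group is tolerated in that setting. Compound 4 is therefore expected to sit between those cases, at roughly 100 nM (range 25 nM to 400 nM), an estimated step of a 10-fold lower number from compound 3 to compound 4 (1.00 log units; beyond the scatter).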

Compound 4, half-maximal inhibitory concentration: 30 nM
Compound 4: the middle estimate sits 3.3-fold (0.52 log units) above what was measured, within the range that was stated.
By their numbers in this assay, from the lowest: compound 2; then compounds 1 and 4 (each within the scatter of the next); then compound 3.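

In this assay, the placement of atoms within the oxadiazole matters on this amine nitrogen in a ring: the two isomers have the same atoms, joined differently, yet the swap gives a large step (a 33-fold lower number from compound 3 to compound 4 (1.52 log units; beyond the scatter)). The 3-isopropyl-1,2,4-oxadiazol-5-yl group also leaves only a modest step from the tert-butoxycarbonyl compound (a 3.0-fold higher number from compound 2 to compound 4 (0.48 log units; beyond the scatter)). With this group in place, diethylamino in place of isopropyl on a sulfonyl sulfur changes nothing measurable (no change at the digits printed from compound 1 to compound 4 (within the scatter)).

Going by these compounds, what a cyclopropyl group in place of the isopropyl on this oxadiazole would give remains open. Nothing shown here explains the difference between the two isomers.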